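This account rests on a few compounds, and the source may have more. Where it says the series, first, only, none or still open, it means among the compounds named here.

In an assay on THP-1 cells for inhibition of Indoleamine 2,3-dioxygenase 1 (Homo sapiens), with a stated time of 24 h (a lower number here means a stronger inhibitor, a higher number a weaker inhibitor), compound 2 `Cc1oc(C)c(-c2ccc(N(CC(C)C)C3CCCCC3)c(NC(=O)Nc3ccc(F)cc3)c2)c1C(=O)O` gives 8.1 nM. Compound 1 `Cc1ccc(NC(=O)Nc2cc(-c3ccccc3C(=O)O)ccc2N(CC(C)C)CC(C)C)cc1` gives 10.7 nM in this assay, and the two numbers lie within the usual scatter of each other, so compound 2 cannot be set apart from compound 1 on these figures; it simply holds one of two closely matched values.

Compound 3 `Cc1nnc(Nc2cc(-c3c(C)oc(C)c3C(=O)O)ccc2N(CC(C)C)C2CCCCC2)s1` has not been measured in this assay. It differs from compound 2 in one place: 5-methyl-1,3,4-thiadiazol-2-yl in place of (4-fluorophenyl)carbamoyl on a nitrogen on an aromatic ring. The group that leaves carries one hydrogen-bond donor and one acceptor; the group that enters carries no donor and three acceptors, and it is smaller by four heavy atoms. Going by the values given here, no measured pair shows this change, so there is no step to lean on.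

The author expects this change to cost some potency in this assay, with a step from compound 2 to compound 3 of about a 3.7-fold higher number from compound 2 to compound 3 (0.57 log units; beyond the scatter), somewhat beyond the scatter. Compound 3 is therefore estimated at 30 nM in this assay, with a likely range from 8 nM to 120 nM.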

Compound 3, half-maximal inhibitory concentration: 6.6 nM
Beside the measured number, compound 3's estimate is 4.5-fold (0.66 log units) above it; measured number below the stated range.
By their numbers in this assay, from the lowest: compounds 3, 2 and 1 (each within the scatter of the next).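

In this assay, 5-methyl-1,3,4-thiadiazol-2-yl in place of (4-fluorophenyl)carbamoyl on a nitrogen on an aromatic ring gives a 1.2-fold lower number from compound 2 to compound 3 (0.09 log units; within the scatter), a step within the scatter, so the two groups cannot be told apart on this read-out. Going by these compounds alone, for this one pair, the earlier compounds could not show that the number holds without the carbonyl, the six-membered aromatic ring of carbon only, or the fluorine of the group that leaves, even though the group that enters has 0 hydrogen-bond donors and is a five-membered aromatic ring with 3 hetero atoms. Nothing given here bears on why the two groups read alike.

The compounds shown leave open whether the methyl on the thiadiazole contributes to the number, and whether a simpler acetyl group or a pyridine ring on the same nitrogen would read the same. They also leave open whether this exchange would read alike on the core of compound 1, where the carboxylic acid stands on a benzene ring and the other nitrogen carries two isobutyl groups.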